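A few compounds are considered here, and "the series" means these few. Any claim that something is new, unique, unknown or untested is made for them only; others in the source may bear on it.

Two compounds share one core and differ only in the group carried by the amine. Compound 1 `CN(CC(N)=O)C[C@@H]1CCCc2cc(S(=O)(=O)c3cccc(F)c3)ccc21` gives 1.26 nM in an assay on isolated protein for displacement of a labelled ligand from 5-hydroxytryptamine receptor 6 (Homo sapiens); on this read-out lower numbers stand for stronger inhibition and higher numbers for weaker inhibition. Compound 2 `COCCNC[C@@H]1CCCc2cc(S(=O)(=O)c3cccc(F)c3)ccc21` gives 0.251 nM in this assay, the lower of the two numbers, and the change a 5.0-fold lower number from compound 1 to compound 2 (0.70 log units; beyond the scatter) shows that this amine substituent matters. Compound 3 `O=S(=O)(O)CCCNC[C@@H]1CCCc2cc(S(=O)(=O)c3cccc(F)c3)ccc21` carries sulfomethyl in place of methoxy on a saturated chain carbon, two bonds along the chain from an amine nitrogen. For the measured compounds named here, no measured step touches this kind of exchange, so the expectation rests loosely on how much the amine group moved the number from compound 1 to compound 2. For compound 3 a weakening step of about a 6.0-fold higher number from compound 2 to compound 3 (0.78 log units; beyond the scatter) is estimated, giving an expected 1.5 nM with a range from 0.3 nM to 8 nM.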

Compound 3, inhibition constant: 1.26 nM
Beside the measured number, compound 3's estimate is 1.2-fold (0.08 log units) above it; measured number inside the range.
By their numbers in this assay, from the lowest: compound 2; then compounds 1 and 3 (each within the scatter of the next).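

Exchanging the methoxy end of compound 2 for sulfomethyl costs potency, with a 5.0-fold higher number from compound 2 to compound 3 (0.70 log units; beyond the scatter). So this end of the chain does respond to what it carries, yet the change gives only a modest step, and compound 3 matches the differently built amine group of compound 1, with no change at the digits printed from compound 1 to compound 3 (within the scatter). No measurement at hand gives a reason for either result. Open, as far as these compounds go, is whether a carboxylic acid or a simple amine at the chain end would behave like the sulfomethyl or the methoxy, and whether a longer chain would shift the number.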